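Hydrogen in place of fluoro: expected cytotoxicity read-out

The source may report more compounds than this note shows. Statements on the series, on what has been measured and on what is new or still open speak of the compounds shown alone.

Two compounds in the series carry numbers in an ADME assay on Vero cells (Chlorocebus sabaeus) for cytotoxicity, read by WST assay, tested at 100 ug/mL; on this read-out higher numbers stand for a weaker effect at the one concentration tested and lower numbers for a stronger effect. Compound 1 `COC(=O)[C@H](COC(=O)/C=C/c1ccccc1)NC(=O)/C=C/c1ccccc1` gives 10.7%. Compound 2 `COC(=O)[C@@H]1COC(/C=C/c2ccc(F)cc2)=N1` gives 18.6%, which puts compound 2 at the upper end of the two numbers, but its gap to compound 1 lies within the scatter, so the two compounds read alike on this assay. Among the measured compounds shown here, no pair of measured compounds differs in a single place, so no step is known from measurement.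

Compound 3 `COC(=O)[C@@H]1COC(/C=C/c2ccccc2)=N1` has not been measured. It differs from compound 2 in one place: hydrogen in place of fluoro on an aromatic carbon. Without any measured step of this kind, the expectation rests only on the two numbers available, both of which are low and alike; nothing in them suggests a move beyond the scatter for the exchange of fluoro for hydrogen. The change expected on this assay is a number 3.6 percentage points lower from compound 2 to compound 3 (within the scatter), small in either direction or none. Compound 3 is expected to give 15% on this assay, estimated between 4% and 30%.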

Compound 3, a percentage reported as activity, at one concentration (the size of the read-out at that concentration, not a potency): 12.4%
The estimate for compound 3 lay 2.6 percentage points above the measured number; measured number inside the range.
By their numbers in this assay, from the lowest: compounds 1, 3 and 2 (each within the scatter of the next).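

In this assay, among the compounds shown here, hydrogen in place of fluoro on an aromatic carbon, para to a large group, gives a number 6.2 percentage points lower from compound 2 to compound 3 (within the scatter), which is the only step measured so far. At this place on the six-membered aromatic ring, the exchange of one fluorine atom for hydrogen therefore does not separate compound 3 from compound 2 on this read-out, so the fluoro is not required for the low number seen with compound 2 and the two compounds read alike. Nothing in the data shown explains why this exchange leaves the read-out within the scatter.

For the compounds shown here, still open is whether a different group at this same place, such as an amine, a methoxy group or a carboxylic acid, would move the read-out beyond the scatter, since fluoro and hydrogen are the only two groups seen here. Going by these compounds alone, also open is whether fluoro in place of hydrogen on the aromatic rings of compound 1 would read alike there too, as the single step comes from the core shared by compound 2 and compound 3 alone.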